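Swapping chloro for methoxy on an aryl-capped tripeptide

The source may hold more compounds than are shown below. What is called first, only, known or untested is meant among the compounds shown, and "the series" means these compounds.

Measured so far:
- compound 1, `CCCC[C@H](NC(=O)[C@H](CCCCN)NC(=O)[C@H](CCCNC(=N)N)NC(=O)/C=C/c1ccccc1)C(N)=O`: 1.26 10^-6 cm/s
- compound 2, `CCCC[C@H](NC(=O)[C@H](CCCCN)NC(=O)[C@H](CCCNC(=N)N)NC(=O)c1ccc(/C=C2\SC(=S)N(c3ccc(Cl)cc3)C2=O)cc1)C(N)=O`: 1.02 10^-6 cm/s
- compound 3, `CCCC[C@H](NC(=O)[C@H](CCCCN)NC(=O)[C@H](CCCNC(=N)N)NC(=O)c1ccc(/C=C2\NC(=S)N(c3ccccc3)C2=O)cc1)C(N)=O`: "impermeable" (no number reported)

Three compounds share the same peptide core and differ only in the group capping its end. In an ADME assay for permeability, using PAMPA (on this read-out higher numbers stand for higher permeability and lower numbers for lower permeability), compound 1 gives 1.26 10^-6 cm/s, and in this assay compound 2 gives 1.02 10^-6 cm/s. These two values lie within the usual scatter of each other, so the measurements do not separate compound 1 from compound 2. Compound 3 was reported as "impermeable" (no number reported), with no number attached, and so cannot be placed against the other two.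

Compound 4, `CCCC[C@H](NC(=O)[C@H](CCCCN)NC(=O)[C@H](CCCNC(=N)N)NC(=O)c1ccc(/C=C2\SC(=S)N(c3ccc(OC)cc3)C2=O)cc1)C(N)=O`, has not yet been measured. It differs from compound 2 in one place: methoxy in place of chloro on an aromatic carbon. For the measured compounds named here, no measured pair in this set shows this exact change, so there is nothing to lean on beyond the values of compounds 1 and 2 themselves, which sit close together despite their very different caps. The expected step from compound 2 to compound 4 is therefore small, with no clear direction, and most likely within the scatter; the step of a 1.1-fold lower number from compound 2 to compound 4 (0.05 log units; within the scatter) is my estimate of it. For compound 4 the estimated value in this assay is 0.9 10^-6 cm/s, with a range from 0.4 10^-6 cm/s to 2 10^-6 cm/s.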

Compound 4, apparent permeability: 0.59 10^-6 cm/s
For compound 4 the middle estimate is 1.5-fold (0.18 log units) above the measured one; the measured number falls inside the stated range.
By their numbers in this assay, from the lowest: compounds 4, 2 and 1 (each within the scatter of the next, the first and the last beyond it).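

For the compounds shown here, this is the first pair in the set that differs in only one place, so the change can be read on its own. In this assay the swap from 4-chlorophenyl to 4-methoxyphenyl gives a 1.7-fold lower number from compound 2 to compound 4 (0.24 log units; within the scatter) on this read-out, and the two compounds are therefore not separated by the measurement. At this place, on an aromatic carbon para to a large group, one chlorine atom can thus give way to a methoxy group, with its two heavy atoms and one hydrogen-bond acceptor, without a change that stands clear of the normal spread of repeated measurements; no measured property of these compounds is available to account for this outcome.

Still open, going by these compounds, is whether a different kind of group on this aromatic carbon, such as an amine or a carboxylic acid, would give a step beyond the scatter. A single pair also cannot tell whether the same swap would read alike on another cap or on a different peptide core.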